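Working notes on cytotoxicity across three ethers and a new analogue

The compounds below may be only part of what the source reports. "The series", "measured", "known", "first", "only" and "open" are said of these compounds alone.

Measured in an ADME assay on L02 cells (Homo sapiens) for cytotoxicity, read by MTT assay; on this read-out higher numbers stand for weaker inhibition and lower numbers for stronger inhibition:
compound 1 `COc1ccc(/C=C/C(=O)c2ccc(OC)c3c2OC(C)(C)C=C3)cc1OCC=C(C)C`: > 10000 nM
compound 2 `C#CCOc1cc(/C=C/C(=O)c2ccc(OC)c3c2OC(C)(C)C=C3)ccc1OC`: > 10000 nM
compound 3 `C=CC(=O)Oc1cc(/C=C/C(=O)c2ccc(OC)c3c2OC(C)(C)C=C3)ccc1OC`: > 10000 nM

Each of these three values is a limit of the assay, not a number. All of them sit at the limit of > 10000 nM in this assay, at which 3 of the 3 values shown sit, so compound 2 stands at the limit and is not separated from compound 1 or compound 3 by any readable amount. The steps a step that the two limits leave unreadable from compound 1 to compound 2, a step that the two limits leave unreadable from compound 1 to compound 3 and a step that the two limits leave unreadable from compound 2 to compound 3 therefore carry no size.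

Compound 4 `COc1ccc(/C=C/C(=O)c2ccc(OC)c3c2OC(C)(C)C=C3)cc1OS(=O)(=O)Cc1ccccc1` differs from compound 2 by benzylsulfonyl in place of propargyl on an oxygen on an aromatic ring. The steps that touch the same oxygen, from compound 1 to compound 2 and from compound 2 to compound 3, are both unreadable, so no direction can be drawn from them for this assay. Compound 4 is expected to give 12000 nM, within 4000 nM to 40000 nM, most likely again as a limit. The step that the limit leaves unreadable from compound 2 to compound 4 is accordingly expected to stay within the scatter.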

Compound 4, half-maximal inhibitory concentration: > 10000 nM
Compound 4 was reported as a limit (the forecaster's own chance of this, stated with the estimate: 70%); the middle value is on the limit's open side.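

Compound 4 is again a limit, and the steps to it from compound 1, compound 2 and compound 3 cannot be read: the limit of > 10000 nM in this assay, at which 4 of the 4 values shown sit.

From the compounds shown here alone, whether the group on that oxygen affects the read-out in this assay at all stays open.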